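The source may hold more compounds than are shown below. What is called first, only, known or untested is meant among the compounds shown, and "the series" means these compounds.

Among the measured compounds shown here, compound 1 `CC(C)Oc1ccccc1-c1ncc(C(=O)O)c(=O)[nH]1` is one of two compounds measured in a functional assay on the whole organism (strain Sprague-Dawley) for inhibition, with Rattus norvegicus as the target, with a stated time of 10 min; on this read-out lower numbers stand for an effect already at smaller amounts and higher numbers for an effect only at larger amounts of compound. In this assay compound 1 gives 0.8 mg/kg, the lowest of the two numbers. For the measured compounds named here, its only measured neighbour is compound 2 `CCSc1ccccc1-c1ncc(C(=O)O)c(=O)[nH]1`, which in this assay gives 25 mg/kg; the step of a 31-fold higher number from compound 1 to compound 2 (1.49 log units; beyond the scatter) is large and well beyond the scatter.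

Compound 3 `CCOC(=O)c1cnc(-c2ccccc2OC(C)C)[nH]c1=O` is not yet measured. It differs from compound 1 in one place: ethyl in place of hydrogen on an oxygen next to a carbonyl group. Going by the values given here, no measured step bears on this change. The single step shown, from compound 1 to compound 2, concerns the group on the aromatic carbon, not the oxygen next to the carbonyl group, so it offers no guide to what the ethyl does here.

With nothing to lean on, the expectation for compound 3 is worded cautiously: a step of size a 2.5-fold higher number from compound 1 to compound 3 (0.40 log units; beyond the scatter) in this assay is expected, toward a somewhat higher number, with a range wide enough to hold an outcome close to compound 1. The estimate for compound 3 in this assay is 2 mg/kg, expected to lie between 0.5 mg/kg and 8 mg/kg.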

Compound 3, dose for 50% inhibition: 2 mg/kg
Compound 3: middle estimate and measured number agree at the digits printed, and the stated range covers the measured number.
By their numbers in this assay, from the lowest: compound 1; then compound 3; then compound 2.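

Among the compounds shown here, this is the first measured change at the oxygen next to the carbonyl group, and it shows that the hydrogen there can give way to ethyl with only a limited loss in this assay: the carboxy to ethoxycarbonyl change gives a 2.5-fold higher number from compound 1 to compound 3 (0.40 log units; beyond the scatter), a modest step that still lies beyond the scatter. That step is much smaller than the one at the aromatic carbon, a 31-fold higher number from compound 1 to compound 2 (1.49 log units; beyond the scatter), so with compound 3 at 2 mg/kg, this oxygen tolerates the added ethyl better than the aromatic carbon tolerates ethylsulfanyl in place of isopropoxy, at least on this pair of changes from compound 1. No measurement given here explains why the ethyl changes the dose so little.

From the compounds shown here alone, a single substituent on this oxygen cannot show a trend, so how methyl, a longer chain such as butyl or a ring-bearing group such as benzyl would read in this assay remains open, as does an amide in place of the ester. Also open, going by these compounds, is whether ethyl on this oxygen would give a step of similar size with ethylsulfanyl on the aromatic carbon.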